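A few compounds are considered here, and "the series" means these few. Any claim that something is new, unique, unknown or untested is made for them only; others in the source may bear on it.

Measured so far:
compound 1 `CC(=O)N(C)C(C)C#CCn1ccnc1`, 3 mg/kg
compound 2 `CC(=O)N(C)C(C)C#CCn1ccnc1C`, > 100 mg/kg
compound 3 `CC(=O)NCC#CCn1ccnc1`, > 100 mg/kg

In a functional assay on the whole organism for agonist activity, with Mus musculus as the target (a higher number here means that more compound is needed for the effect, a lower number that less compound is needed), compound 1 gives 3 mg/kg. For compound 2 the value > 100 mg/kg is a limit of the assay, not a number. For compound 3 the value > 100 mg/kg is likewise a limit of the assay. The change methyl in place of hydrogen on an aromatic carbon gave an at least 33-fold higher number from compound 1 to compound 2 (1.52 log units; beyond the scatter). The difference between the two cores of compound 1 and compound 3 is not broken down here. Compound 4 `CC(=O)NCC#CCn1cncc1C`, not yet measured, carries the same kind of change, (methyl in place of hydrogen on an aromatic carbon), though the place is not the same: in compound 2 the methyl sits between two ring nitrogen atoms, next to the ring atom that bears a large group, while in compound 4 it sits next to the ring nitrogen, next to the ring atom that bears a group of 8 heavy atoms, two ring bonds from the ring nitrogen. Compound 3 already sits at the limit of > 100 mg/kg in this assay, at which 2 of the 3 values shown sit, and the earlier step of the same kind was large. The expected step is a step that the limit leaves unreadable from compound 3 to compound 4. For compound 4 the expected value in this assay is 300 mg/kg, most likely reported again only as a limit, within 100 mg/kg to 1000 mg/kg.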

Compound 4, dose for half-maximal effect: > 100 mg/kg
Compound 4: only a limit was reported; the forecaster's own chance of this, stated with the estimate: 90%; the middle value is on the limit's open side.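

The step from compound 3 to compound 4 cannot be read, as both values are limits of the assay: the limit of > 100 mg/kg in this assay, at which 3 of the 4 values shown sit.

The compounds shown leave open what methyl at the place it holds in compound 4 does on the core of compound 1 in this assay.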